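The source may hold more compounds than are shown below. What is called first, only, known or untested is meant among the compounds shown, and "the series" means these compounds.

Working notes on the series in a functional assay on HOS cells (Homo sapiens) for antiproliferative activity, read by sulforhodamine B assay; on this read-out lower numbers stand for stronger inhibition of growth and higher numbers for weaker inhibition of growth. Compound 1 `O[C@H]1CO[C@H](COCc2ccccc2)[C@@H](OCc2ccccc2)[C@@H]1OCc1ccccc1` gives 37900 nM, compound 2 `CC(C)C[C@@H]1O[C@H](COCc2ccccc2)[C@@H](OCc2ccccc2)[C@H](OCc2ccccc2)[C@H]1O` gives 45200 nM, and compound 3 `C=CC[C@@H]1O[C@H](COCc2ccccc2)[C@@H](OCc2ccccc2)[C@H](OCc2ccccc2)[C@H]1O` gives 44100 nM. Compound 3 therefore lies within the scatter of both other compounds, and the three values cannot be ranked.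

The next compound is compound 4 `OCC[C@@H]1O[C@H](COCc2ccccc2)[C@@H](OCc2ccccc2)[C@H](OCc2ccccc2)[C@H]1O`. The change is hydroxymethyl in place of vinyl on a saturated chain carbon bound to a saturated ring carbon, which also reads as allyl to 2-hydroxyethyl. The closest measured precedent is a 1.0-fold lower number from compound 2 to compound 3 (0.01 log units; within the scatter), a change at the same place. Also relevant are a 1.2-fold higher number from compound 1 to compound 2 (0.08 log units; within the scatter) and a 1.2-fold higher number from compound 1 to compound 3 (0.07 log units; within the scatter). Going by these compounds, all three steps are within the scatter, but none brings in hydroxymethyl, so this particular change remains untested. The estimated step is a 1.1-fold higher number from compound 3 to compound 4 (0.04 log units; within the scatter), with no size beyond the scatter expected. For compound 4 the expected value is 48000 nM, with an estimated range from 27000 nM to 85000 nM.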

Compound 4, concentration for 50% growth inhibition: 39700 nM
Compound 4: middle estimate off by 1.2-fold (0.08 log units), on the high side; low and high end bracket the measured number.
By their numbers in this assay, from the lowest: compounds 1, 4, 3 and 2 (each within the scatter of the next).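

In this assay, among the compounds shown here, hydroxymethyl in place of vinyl on a saturated chain carbon bound to a saturated ring carbon gives a 1.1-fold lower number from compound 3 to compound 4 (0.05 log units; within the scatter) and hydroxymethyl in place of isopropyl gives a 1.1-fold lower number from compound 2 to compound 4 (0.06 log units; within the scatter) so the only group here with a hydrogen-bond donor and acceptor stays within the scatter of the groups without them. Set against hydrogen on a saturated ring carbon, 2-hydroxyethyl gives a 1.0-fold higher number from compound 1 to compound 4 (0.02 log units; within the scatter) and thus joins isobutyl and allyl in showing no readable difference from hydrogen. No evidence is at hand that bears on this result.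

Going by these compounds, whether an amine, a carboxylic acid or a longer chain ending in hydroxyl would leave the scatter at this place stays open. No step shown here lies beyond the scatter, so the series gives this place no measured direction yet.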